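Swapping 4-fluorophenyl for ethyl on a weak inhibitor

The compounds below may be only part of what the source reports. "The series", "measured", "known", "first", "only" and "open" are said of these compounds alone.

- Compound 1 `O=c1oc2ccccc2c(N2CCN(C(c3ccc(F)cc3)c3ccc(F)cc3)CC2)c1CO` gives 29400 nM
- Compound 2 `O=c1oc2ccccc2c(N2CCN(c3ccc(F)cc3)CC2)c1CO` gives > 50000 nM

The test is a functional assay on WM1361 cells (Homo sapiens) for inhibition, read by MTT assay, with a stated time of 24 h; a lower number here means a stronger inhibitor, a higher number a weaker inhibitor. Compound 2 gives > 50000 nM in this assay, and this is a limit of the assay, not a number.

Compound 3 `CCN1CCN(c2c(CO)c(=O)oc3ccccc23)CC1` carries ethyl in place of 4-fluorophenyl on an amine nitrogen in a ring. Going by the values given here, no measured step shows what such a swap does. Compound 1 reaches only 29400 nM, so weak inhibition is expected to persist in this assay, with no clear change in either direction. The expected change is a number no higher from compound 2 to compound 3 (the limit leaves the size open). Compound 3 is estimated at 50000 nM, with an expected range of 20000 nM to 100000 nM.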

Compound 3, half-maximal inhibitory concentration: > 100000 nM
Compound 3 ended at the assay's limit; the forecaster's own chance of this, stated with the estimate: 60%; middle value at least 2.0-fold (0.30 log units) away from the limit.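

Going by these compounds alone, compound 2 and compound 3 both gave only limits of the assay, not numbers, so no step between them can be read. The compounds shown leave open whether swapping 4-fluorophenyl for ethyl changes inhibition at all.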